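Swapping methoxy for fluoro on a thiourea aryl ring

A few compounds are considered here, and "the series" means these few. Any claim that something is new, unique, unknown or untested is made for them only; others in the source may bear on it.

Of the compounds shown here, two from this series have been tested in a functional assay on MCF7 cells (Homo sapiens) for inhibition, read by CCK-8 assay, with a stated time of 48 h; a higher number here means a weaker inhibitor, a lower number a stronger inhibitor. Compound 1 `O=C(NC(=S)Nc1ccc(F)cc1)c1cn(-c2ccccc2)nc1-c1ccccc1` gives 6820 nM in this assay. Compound 2 `COc1ccc(NC(=S)NC(=O)c2cn(-c3ccccc3)nc2-c2ccc(OC)cc2)cc1` gives 4210 nM in this assay, which is the lower of the two numbers, though the gap between compound 2 and compound 1 lies within the usual scatter, so the two values cannot be told apart with confidence.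

Compound 3 `COc1ccc(-c2nn(-c3ccccc3)cc2C(=O)NC(=S)Nc2ccc(F)cc2)cc1` has not yet been measured in this assay. It differs from compound 2 in one place: fluoro in place of methoxy on an aromatic carbon. The rest of the molecule, including the methoxy on the aryl ring attached to the shared core, is kept.

Going by the values given here, no comparison between measured compounds isolates this change. Since compound 1, which carries the same fluoro on its thiourea aryl ring, and compound 2 sit within the scatter of each other, no step beyond the scatter is expected here. Compound 3 is therefore estimated at 5000 nM, with a range from 2000 nM to 12000 nM, meaning an expected step of a 1.2-fold higher number from compound 2 to compound 3 (0.07 log units; within the scatter).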

Compound 3, half-maximal inhibitory concentration: 4990 nM
The estimate for compound 3 lay 1.0-fold (0.00 log units) above the measured number, within the range that was stated.
By their numbers in this assay, from the lowest: compounds 2, 3 and 1 (each within the scatter of the next).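

In this assay, fluoro in place of methoxy on the thiourea aryl ring, at the place para to a large group, gives a 1.2-fold higher number from compound 2 to compound 3 (0.07 log units; within the scatter), so this swap alone does not separate the two compounds. Compound 3 also forms a second single-place pair: with fluoro kept on the thiourea aryl ring, methoxy in place of hydrogen on the aryl ring attached to the shared core gives a 1.4-fold lower number from compound 1 to compound 3 (0.14 log units; within the scatter), so neither of the two sites yields a difference that can be read from these numbers. No other measurement bears on this result, so nothing can be said about why these compounds read alike.

The thiourea aryl ring carries only methoxy or fluoro in the compounds shown, so it remains open whether an amine, a carboxylic acid or a longer chain at that place would give a number beyond the scatter. The aryl ring attached to the shared core carries only hydrogen or methoxy here, which leaves open how a group such as a nitrile or a hydroxyl would read at that site.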